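The source may report more compounds than this note shows. Statements on the series, on what has been measured and on what is new or still open speak of the compounds shown alone.

Measured so far in an assay on HEK-293T cells for inhibition of diacylglycerol lipase-alpha (Homo sapiens), read by colorimetric assay; on this read-out higher numbers stand for weaker inhibition and lower numbers for stronger inhibition:
- compound 1, `Cn1nnc(C(=O)CCCCCCc2ccccc2)n1`: compound 1 gives > 10000 nM, a limit of the assay and not a number.
- compound 2, `O=C(CCCCCCc1ccccc1)c1nc(Br)co1`: compound 2 gives > 10000 nM, likewise only a limit.

Within the data shown here, compound 2 stands at the limit, and compound 1 sits at the same limit, so the one measured step, a step that the two limits leave unreadable from compound 1 to compound 2, cannot be read in either direction; both values sit at the limit of > 10000 nM in this assay, at which 2 of the 2 values shown sit.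

Compound 3, `Cc1coc(C(=O)CCCCCCc2ccccc2)n1`, differs from compound 2 in one place: methyl in place of bromo on an aromatic carbon. Among the measured compounds shown here, no measured step bears on a methyl in place of bromo, and the single step in hand is unreadable. The series gives no direction for this change, and the limit at which compound 2 sits leaves no room for a weaker reading to register. Compound 3 is therefore expected to stay at or near the limit, with a step that the limit leaves unreadable from compound 2 to compound 3 as the expected step. The estimate for compound 3 is 20000 nM, between 5000 nM and 100000 nM, most likely reported again only as a limit.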

Compound 3, half-maximal inhibitory concentration: > 10000 nM
Compound 3: no number, only a limit (the forecaster's own chance of this, stated with the estimate: 85%); the middle value is on the limit's open side.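

In this assay compound 3 gives > 10000 nM as a limit and not a number. Among these compounds, no step among compound 1, compound 2 and compound 3 can be read: the limit of > 10000 nM in this assay, at which 3 of the 3 values shown sit.

On these data alone, whether this assay gives a readable value for any group on the carbonyl carbon of the shared core stays open.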